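The source may report more compounds than this note shows. Statements on the series, on what has been measured and on what is new or still open speak of the compounds shown alone.

Values in an ADME assay on microsomes from liver (Homo sapiens) for metabolic stability, with a stated time of 10 min; on this read-out lower numbers stand for a less stable compound and higher numbers for a more stable compound:
- compound 1 `CS(=O)(=O)c1nn2cc(-c3cc4ccccc4o3)nc2s1`: "not determined" (no result reported)
- compound 2 `COc1cc(OCc2cccc(CCc3ccccc3)c2)c2cc(-c3cn4nc(OC)sc4n3)oc2c1`: 99%
- compound 3 `COc1cc(OCc2cccc(Oc3ccccc3)c2)c2cc(-c3cn4nc(OC)sc4n3)oc2c1`: 86%

On this assay, compound 1 has no number to start from, as its entry reads "not determined" (no result reported). Compound 4 `CCOc1nn2cc(-c3cc4ccccc4o3)nc2s1` keeps the core of compound 1 and carries ethoxy in place of methylsulfonyl on an aromatic carbon. Among the compounds with values here, the only measured step, a number 13 percentage points lower from compound 2 to compound 3 (beyond the scatter), is modest and swaps different groups, so it says little about this change. With no starting value, no size or direction of step can be expected. The expectation rests loosely on compound 2 at 99% and compound 3 at 86%, which differ from compound 4 in much of their structure, so the range stays wide. The estimated value for compound 4 is 80%, expected between 55% and 98%.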

Compound 4, percent of the compound remaining: 57%
Compound 4: the middle estimate sits 23 percentage points above what was measured; low and high end bracket the measured number.
By their numbers in this assay, from the lowest: compound 4; then compound 3; then compound 2.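

Within the data shown here, compound 1 has no number in this assay, so no step to compound 4 can be read. Going by these compounds, what ethoxy in place of methylsulfonyl does to this read-out stays open, and no supporting data bear on it.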